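The source may hold more compounds than are shown below. What is called first, only, known or untested is meant among the compounds shown, and "the series" means these compounds.

Compound 1, `Cc1cc(C(=O)Nc2ccccn2)nn1Cc1cc(Cl)ccc1OCc1ccccc1`, carries a (pyridin-2-yl)carbamoyl group on an aromatic carbon of the shared core. In a physicochemical assay for lipophilicity, at pH 7.4 (a higher number here means a more lipophilic compound, a lower number a more polar compound), compound 1 reaches the limit > 3.7, which is a limit of the assay and not a number. Compound 2, `Cc1cc(NC(=O)C2CCCC2)nn1Cc1cc(Cl)ccc1OCc1ccccc1`, gives 3.5 in this assay, and compound 3, `Cc1cc(NC(=O)CC2CCCCC2)nn1Cc1cc(Cl)ccc1OCc1ccccc1`, gives 3.2. The step of a number at least 0.20 log units lower from compound 1 to compound 2 (that floor lies within the scatter) and the step of a number at least 0.50 log units lower from compound 1 to compound 3 (beyond the scatter) both point downward, while the step of a number 0.30 log units lower from compound 2 to compound 3 (within the scatter) stays within the scatter. Compound 4, `Cc1cc(NC(=O)O[C@H]2CCOC2)nn1Cc1cc(Cl)ccc1OCc1ccccc1`, is not yet measured; it differs from compound 1 as follows: (((oxolan-3-yl)oxy)carbonyl)amino in place of (pyridin-2-yl)carbamoyl on an aromatic carbon. The steps from compound 1 to compounds 2 and 3 bear on this change, since each also removes the (pyridin-2-yl)carbamoyl group, and the entering (((oxolan-3-yl)oxy)carbonyl)amino group carries more oxygen than either of those replacements. A downward step in this assay at least as large as those is therefore expected. For compound 4 the expected step is a number at least 0.90 log units lower from compound 1 to compound 4 (beyond the scatter). Compound 4 is expected to give 2.8, within the range 2.3 to 3.4.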

Compound 4, distribution coefficient: 2.7
Compound 4: middle estimate off by 0.10 log units, on the high side; low and high end bracket the measured number.
By their numbers in this assay, from the lowest: compound 4; then compounds 3 and 2 (each within the scatter of the next). At a limit, above all of these: compound 1.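

On the carbonyl carbon, (oxolan-3-yl)oxy in place of a carbon group gives a shift in this assay that is beyond the scatter: a number 0.50 log units lower from compound 3 to compound 4 (beyond the scatter) and a number 0.80 log units lower from compound 2 to compound 4 (beyond the scatter), while cyclohexylmethyl in place of cyclopentyl at the same carbon stayed within the scatter. Measured against the starting group, the change gives the largest floor so far, a number at least 1.00 log units lower from compound 1 to compound 4 (beyond the scatter). Compound 1 stands at a limit, so this step is known only as a floor: the limit of > 3.7 in this assay, at which 1 of the 4 values shown sits.

The compounds shown leave open whether the step follows the oxygen in the ring or the oxygen linking that ring to the carbonyl, a question that a cyclopentyloxy group on the same carbon would separate. Also open, from the compounds shown here alone, is how an amine or a carboxylic acid on the oxolane ring would read in this assay.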